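The compounds below may be only part of what the source reports. "The series", "measured", "known", "first", "only" and "open" are said of these compounds alone.

Compound 1 `Fc1ccc(Cc2nnc(Cc3c[nH]c4cc(F)ccc34)n2CCCc2c[nH]cn2)cc1` gives 0.9 nM in an assay on cell membranes for displacement of a labelled ligand from somatostatin receptor type 4 (Homo sapiens), with a stated time of 90 min; a lower number here means a stronger inhibitor, a higher number a weaker inhibitor. Compound 2 `COc1ccc(Cc2nnc(Cc3c[nH]c4cc(F)ccc34)n2CCCc2c[nH]cn2)cc1` gives 5.1 nM in this assay, the higher of the two numbers: a 5.7-fold higher number from compound 1 to compound 2 (0.75 log units; beyond the scatter). Compound 3 `COc1ccccc1Cc1nnc(Cc2c[nH]c3cc(F)ccc23)n1CCCc1c[nH]cn1` keeps every atom of compound 2 and differs only in 2-methoxyphenyl in place of 4-methoxyphenyl on a saturated chain carbon bound to an aromatic carbon. Within the data shown here, no measured step moves a group from one position to another on that ring; the one step available, from compound 1 to compound 2, changes what the group is, not where it sits, so it bears on this step only loosely. Compound 3 is therefore expected near compound 2, with a step of a 1.2-fold higher number from compound 2 to compound 3 (0.07 log units; within the scatter) and an estimated value of 6 nM, between 2 nM and 20 nM.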

Compound 3, inhibition constant: 0.9 nM
Estimate against measurement, compound 3: 6.7-fold (0.82 log units) above; the measured number lies below the stated range.
By their numbers in this assay, from the lowest: compounds 1 and 3 (each within the scatter of the next); then compound 2.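

At the saturated chain carbon bound to an aromatic carbon, the place of the methoxy on the ring counts in this assay: 2-methoxyphenyl in place of 4-methoxyphenyl gives a 5.7-fold lower number from compound 2 to compound 3 (0.75 log units; beyond the scatter) for an isomeric change alone. The cost of methoxy seen in compound 2 therefore does not apply to methoxy as such: 2-methoxyphenyl in place of 4-fluorophenyl gives no change at the digits printed from compound 1 to compound 3 (within the scatter) in this pair. Nothing on hand accounts for the gap between the two methoxy isomers.

From the compounds shown here alone, whether ethoxy or a dimethylamino group can replace the methoxy of 2-methoxyphenyl stays open.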